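This account rests on a few compounds, and the source may have more. Where it says the series, first, only, none or still open, it means among the compounds named here.

In a functional assay on DU-145 cells (Homo sapiens) for inhibition, read by trypan blue exclusion, with a stated time of 72 h (on this read-out lower numbers stand for stronger inhibition and higher numbers for weaker inhibition), compound 1 (`Cn1c(=O)c(C(=O)Nc2ccc(F)cc2F)cc2cnc(Nc3ccc4[nH]ccc4c3)nc21`) gives 5000 nM, and compound 2 (`Cn1c(=O)c(S(=O)(=O)c2ccc(Cl)cc2)cc2cnc(Nc3ccc4[nH]ccc4c3)nc21`) gives 250 nM. Compound 2 therefore holds the lower of the two numbers. Among the compounds with values here, the only measured step is a 20-fold lower number from compound 1 to compound 2 (1.30 log units; beyond the scatter), which is large and beyond the scatter. That step exchanged a whole carbamoyl-bearing group for a sulfonyl-bearing one, so it gives little guidance on the swap of a single halogen.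

Compound 3 (`Cn1c(=O)c(S(=O)(=O)c2ccc(F)cc2)cc2cnc(Nc3ccc4[nH]ccc4c3)nc21`) keeps the shared core and the sulfonyl group of compound 2, and the change is confined to one atom: fluoro in place of chloro on an aromatic carbon. This puts fluoro in place of chloro on an aromatic carbon, para to a large group. Within the data shown here, no measured pair changes this halogen alone, so the data offer no direct precedent. With compound 2 at 250 nM as the anchor, no step beyond the scatter is expected, and no direction is favoured. The expected change is a 1.2-fold higher number from compound 2 to compound 3 (0.08 log units; within the scatter). Compound 3 is estimated at 300 nM, with an expected range from 120 nM to 800 nM.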

Compound 3, half-maximal inhibitory concentration: 300 nM
The estimate for compound 3 equals the measured number at the digits printed; low and high end bracket the measured number.
By their numbers in this assay, from the lowest: compounds 2 and 3 (each within the scatter of the next); then compound 1.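

In this assay, within the data shown here, the first pair to change this halogen alone, on the aromatic carbon para to a large group, shows a 1.2-fold higher number from compound 2 to compound 3 (0.08 log units; within the scatter), so at this place fluoro and chloro cannot be told apart on these numbers. The large step seen earlier also holds with fluoro in the sulfonyl group, as a 17-fold lower number from compound 1 to compound 3 (1.22 log units; beyond the scatter) shows; compounds 2 and 3 both lie well under compound 1, and so the advantage of the sulfonyl-bearing group over the carbamoyl-bearing group does not rest on chlorine alone. No independent measurement bears on these results, so what lies behind either step remains unexplained.

The compounds shown leave open whether this place accepts groups other than these two halogens, such as a methoxy group, a nitrile, an amine or a carboxylic acid, or a bare hydrogen. They also leave the linking group and the aryl ring entangled, and a (2,4-difluorophenyl)sulfonyl or a (4-fluorophenyl)carbamoyl group on the shared core would be needed to separate the contribution of each.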